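The source may report more compounds than this note shows. Statements on the series, on what has been measured and on what is new or still open speak of the compounds shown alone.

Series on a shared core, `CC1=CC[C@H](C(C)(C)NC(=S)N/N=C/c2ccc(O)cc2)CC1` being compound 1. In a functional assay on PC-3 cells (Homo sapiens) for inhibition, read by sulforhodamine B assay, with a stated time of 48 h (a higher number here means a weaker inhibitor of growth, a lower number a stronger inhibitor of growth), compound 1 gives 600 nM. Compound 2, `CC1=CC[C@H](C(C)(C)NC(=S)N/N=C/c2ccccc2O)CC1`, reaches a limit of the assay and no number, giving < 40 nM in this assay. Compound 3, `CC1=CC[C@H](C(C)(C)NC(=S)N/N=C/c2ccc(F)cc2)CC1`, likewise sits at a limit, with < 40 nM in this assay. The step of an at least 15-fold lower number from compound 1 to compound 2 (1.17 log units; beyond the scatter) and the step of an at least 15-fold lower number from compound 1 to compound 3 (1.17 log units; beyond the scatter) are both large; the step that the two limits leave unreadable from compound 2 to compound 3 cannot be read, since both its ends rest on the limit noted in the limit of < 40 nM in this assay, at which 2 of the 3 values shown sit. Compound 3 thus stands at the floor of the numbers shown, where two of the three compounds sit.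

Compound 4, `CC1=CC[C@H](C(C)(C)NC(=S)N/N=C/c2ccc(Cl)cc2)CC1`, is not yet measured; it differs from compound 3 by chloro in place of fluoro on an aromatic carbon. For the measured compounds named here, no measured step exchanges one halogen for another on this ring, so none bears directly on it; the only steps touching compound 3 are the large one from compound 1 and the unreadable one from compound 2. The expectation is a step of no size beyond the scatter, so compound 4 is expected to remain at the limit, the expected step being a step that the limit leaves unreadable from compound 3 to compound 4. For compound 4 the estimate in this assay is 30 nM, between 10 nM and 80 nM.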

Compound 4, concentration for 50% growth inhibition: 50 nM
Estimate against measurement, compound 4: 1.7-fold (0.22 log units) below, and the stated range covers the measured number.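

In this assay, replacing hydroxy with a halogen at this place, on an aromatic carbon para to a large group, now has a readable size, a 12-fold lower number from compound 1 to compound 4 (1.08 log units; beyond the scatter), whereas the fluoro step rested on a limit. Exchanging fluoro for chloro gives an at least 1.2-fold higher number from compound 3 to compound 4 (0.09 log units; that floor lies within the scatter), and going from 2-hydroxyphenyl to 4-chlorophenyl gives an at least 1.2-fold higher number from compound 2 to compound 4 (0.09 log units; that floor lies within the scatter). These two steps can be read only as floors, and no true size or order can be given for them because one end of each rests on the limit: the limit of < 40 nM in this assay, at which 2 of the 4 values shown sit.

From the compounds shown here alone, the true distance of compound 2 and compound 3 from compound 4 remains open. So does how a methoxy group, an amine or a bromo group at this same place would compare with chloro.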